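Solubility at the assay limit across the anilino series

The source may report more compounds than this note shows. Statements on the series, on what has been measured and on what is new or still open speak of the compounds shown alone.

Compound 3 `CCc1ccccc1Nc1ncc2cc(Oc3ccnc(C(=O)NC)c3)ccc2n1` is one of three measured congeners of the shared core. In a physicochemical assay for solubility, at pH 7 (on this read-out lower numbers stand for lower solubility and higher numbers for higher solubility), compound 3 gives < 1000 nM, which is a limit of the assay and not a number. Compound 1 `CNC(=O)c1cc(Oc2ccc3nc(Nc4ccccc4)ncc3c2)ccn1` likewise returns only a limit in this assay, < 1000 nM. Compound 2 `CNC(=O)c1cc(Oc2ccc3nc(Nc4ccccc4Br)ncc3c2)ccn1` also sits at a limit in this assay, < 1000 nM. The three steps among them therefore cannot be read for size: a step that the two limits leave unreadable from compound 1 to compound 2, a step that the two limits leave unreadable from compound 1 to compound 3 and a step that the two limits leave unreadable from compound 2 to compound 3. Among the compounds with values here, the one regularity in the numbers is the limit of < 1000 nM in this assay, at which 3 of the 3 values shown sit.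

Compound 4 `CNC(=O)c1cc(Oc2ccc3nc(Nc4ccccc4Oc4ccccc4)ncc3c2)ccn1` is the next member; it differs from compound 3 by phenoxy in place of ethyl on an aromatic carbon. Within the data shown here, none of the measured steps gives a size or a direction, so they offer no lever for this change; the only bearing is that hydrogen, bromo and ethyl in the varied place all return the same limit. Compound 4 in this assay is therefore expected to show no step beyond the scatter, a step that the limit leaves unreadable from compound 3 to compound 4, and most probably a further limit. Compound 4 is estimated at 300 nM, with a range from 40 nM to 1000 nM.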

Compound 4, solubility: < 1000 nM
Compound 4: no number, only a limit (the forecaster's own chance of this, stated with the estimate: 85%); the middle value lies beyond the limit too.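

Compound 4 also returns only a limit in this assay, and its steps from compound 1, compound 2 and compound 3 cannot be read for size; the one regularity stays: the limit of < 1000 nM in this assay, at which 4 of the 4 values shown sit.

The compounds shown leave open whether any group in the varied place changes the read-out, and by how much.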